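This account rests on a few compounds, and the source may have more. Where it says the series, first, only, none or still open, it means among the compounds named here.

Measured compounds:
- compound 1, `CCCCCCCC/C=C\CCCCCCCC(=O)OC[C@H]1O[C@@H](n2ccc(N)nc2=O)[C@@H](O)[C@@H]1OC(=O)CCCCCCC/C=C\CCCCCCCC`: 1.1 ug/mL
- compound 2, `CCCC(=O)OC[C@H]1O[C@@H](n2ccc(N)nc2=O)[C@@H](O)[C@@H]1OC(=O)CCC`: 0.11 ug/mL
- compound 3, `CCCCCC(=O)O[C@H]1[C@H](O)[C@H](n2ccc(N)nc2=O)O[C@@H]1CO`: 0.05 ug/mL

In a functional assay on HeLa cells (Homo sapiens) for cytotoxicity, read by cell counting, with a stated time of 48 h (a lower number here means that less compound is needed, a higher number that more compound is needed for the effect), compound 3 gives the lowest of the three numbers. Its nearest neighbour is compound 2, and the gap between them lies beyond the scatter; compound 1 stands furthest away, with a gap that is clearly beyond the scatter. The three compounds share the same core and differ in the ester groups attached to it: compound 1 carries two long unsaturated chains, compound 2 two short chains, compound 3 a single chain of moderate length.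

Compound 4, `CCCCCCCCCCCC(=O)O[C@H]1[C@H](O)[C@H](n2ccc(N)nc2=O)O[C@@H]1CO`, keeps the single-ester arrangement of compound 3 and differs from it in one place: hexyl in place of hydrogen on a saturated chain carbon, five bonds along the chain from a carbonyl carbon. Among the compounds with values here, no measured pair shows this exact step. The expectation rests on compound 1, which with its two long chains gives 1.1 ug/mL in this assay, the highest number of the set, whereas compound 2 with its short chains gives 0.11 ug/mL. A modest step upward, likely beyond the scatter, is therefore expected from compound 3 to compound 4, a 3.0-fold higher number from compound 3 to compound 4 (0.48 log units; beyond the scatter). Compound 4 is estimated at 0.15 ug/mL, within a range from 0.05 ug/mL to 0.5 ug/mL.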

Compound 4, concentration for half-maximal effect: 0.08 ug/mL
Compound 4: the middle estimate sits 1.9-fold (0.27 log units) above what was measured; the measured number falls inside the stated range.
By their numbers in this assay, from the lowest: compounds 3, 4 and 2 (each within the scatter of the next, the first and the last beyond it); then compound 1.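

In this assay, hexyl in place of hydrogen on a saturated chain carbon, five bonds along the chain from a carbonyl carbon, gives a 1.6-fold higher number from compound 3 to compound 4 (0.20 log units; within the scatter), so this position takes the hexyl group with no change beyond the scatter. Within the data shown here, the earlier compounds could not show this, since compound 1, compound 2 and compound 3 differ from one another in more than one place, and this is the first step that changes a single place. Nothing measured here offers an explanation for this result.

On these data alone, whether an amine, a carboxylic acid or a longer chain in the same place would also stay within the scatter of compound 3 remains open. Among these compounds, also open is how a second ester group bears on the numbers, as no single step isolates it.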